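The source may hold more compounds than are shown below. What is called first, only, known or untested is meant among the compounds shown, and "the series" means these compounds.

In a functional assay on thoracic aorta (Rattus norvegicus, strain Wistar), with a stated time of 15 min (on this read-out higher numbers stand for an effect only at larger amounts of compound and lower numbers for an effect already at smaller amounts), compound 3 (`Cc1ccc(S(=O)(=O)N(C)C(=O)NC(C)c2cc(Br)ccc2OC(C)C)cc1`) gives 34700 nM. Compound 1 (`CCOc1ccc(Br)cc1C(C)NC(=O)N(C)S(=O)(=O)c1ccc(Cl)cc1`) gives 55700 nM, within the usual scatter of compound 3, so these two cannot be ranked. Compound 2 (`CC(NC(=O)N(C)S(=O)(=O)c1ccc(Cl)cc1)c1cc(Br)ccc1OCc1ccccc1`) gives 146000 nM, a higher number than either of them and beyond the scatter, meaning that it takes more compound to produce the effect.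

Compound 4 (`CC(C)Oc1ccc(Br)cc1C(C)NC(=O)N(C)S(=O)(=O)c1ccc(Cl)cc1`) changes compound 3 in one place: chloro in place of methyl on an aromatic carbon. In short, 4-methylphenyl becomes 4-chlorophenyl. Among the measured compounds shown here, the only measured step that changes a single place is a 2.6-fold higher number from compound 1 to compound 2 (0.42 log units; beyond the scatter). That modest step involves phenyl in place of methyl on a saturated chain carbon, not this change on the aromatic ring, so it offers no direct guide. Compound 1 does carry the 4-chlorophenyl group and, at 55700 nM, lies within the scatter of compound 3, although that pair is not a single-place step. On this limited evidence, no step beyond the scatter is expected in this assay, and no clear direction can be given. The expected change is a 1.2-fold higher number from compound 3 to compound 4 (0.06 log units; within the scatter). For compound 4 the estimated value is 40000 nM, with an expected range from 16000 nM to 100000 nM.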

Compound 4, half-maximal effective concentration: 43200 nM
Beside the measured number, compound 4's estimate is 1.1-fold (0.03 log units) below it; the range from low to high includes it.
By their numbers in this assay, from the lowest: compounds 3, 4 and 1 (each within the scatter of the next); then compound 2.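

In this assay, the exchange of 4-methylphenyl for 4-chlorophenyl gives a 1.2-fold higher number from compound 3 to compound 4 (0.10 log units; within the scatter) and so leaves no readable difference: on this aromatic carbon, methyl and chloro cannot be told apart, at least with an isopropyl group on the oxygen. Compound 4 also adds to what is known about that oxygen, since with the 4-chlorophenyl group held fixed, isopropyl in place of benzyl gives a 3.4-fold lower number from compound 2 to compound 4 (0.53 log units; beyond the scatter) while one extra methyl on the chain, which turns ethyl into isopropyl, gives a 1.3-fold lower number from compound 1 to compound 4 (0.11 log units; within the scatter) and so no readable change. Across compounds 1, 2 and 4, then, ethyl and isopropyl on the oxygen behave alike, and only the benzyl group of compound 2 stands apart, needing more compound for the same effect.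

Nothing available here explains why these steps have the sizes they do. Still open, going by these compounds, is whether a fluoro or a methoxy group on the same aromatic carbon would also go unnoticed, and whether an oxygen carrying a longer chain, such as butyl, or a chain ending in an amine would follow ethyl and isopropyl or follow benzyl.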